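From ethoxycarbonyl to propargyloxy with the fluoro group kept

This account rests on a few compounds, and the source may have more. Where it says the series, first, only, none or still open, it means among the compounds named here.

Within the data shown here, in a functional assay on the whole organism for inhibition, with Scenedesmus acutus as the target (on this read-out higher numbers stand for weaker inhibition and lower numbers for stronger inhibition), compound 1 (`CCOC(=O)c1cc(N2C(=O)C3=C(CCCC3)C2=O)c(F)cc1Cl`) gives 57.5 nM, the lowest of the three numbers so far. Compound 2 (`CCOC(=O)c1cc(N2C(=O)C3=C(CCCC3)C2=O)ccc1Cl`) gives 1910 nM and compound 3 (`CCCCCOC(=O)c1cc(N2C(=O)C3=C(CCCC3)C2=O)ccc1Cl`) gives 4470 nM, both beyond the scatter from compound 1.

Compound 4 (`C#CCOc1cc(N2C(=O)C3=C(CCCC3)C2=O)c(F)cc1Cl`) keeps the core of compound 1 and its chloro and fluoro groups. It carries propargyloxy in place of ethoxycarbonyl on an aromatic carbon, ortho to a chloro group and para to a fluoro group: propargyloxy in place of ethoxycarbonyl on an aromatic carbon.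

Among the measured compounds shown here, no measured step makes this exchange, so the evidence is indirect. Removing the fluoro group gave a 33-fold higher number from compound 1 to compound 2 (1.52 log units; beyond the scatter), a large step, but compound 4 retains that group, so a step of this kind is not expected here. Extending the chain of the ethoxycarbonyl group gave a 2.3-fold higher number from compound 2 to compound 3 (0.37 log units; beyond the scatter), a modest step, and this is the only measured change at the position now being altered. It leaves the carbonyl in place, however, so it covers the replacement of the whole group only loosely. The data give no direction, and no step beyond the scatter is expected in this assay, with wide uncertainty on both sides. The expected change is a 1.3-fold lower number from compound 1 to compound 4 (0.11 log units; within the scatter). For compound 4 the estimated value is 45 nM, with an expected range of 10 nM to 200 nM.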

Compound 4, half-maximal inhibitory concentration: 15.9 nM
Estimate against measurement, compound 4: 2.8-fold (0.45 log units) above, within the range that was stated.
By their numbers in this assay, from the lowest: compound 4; then compound 1; then compound 2; then compound 3.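

Working notes on the position ortho to the chloro group and para to the fluoro group: in this assay the whole ethoxycarbonyl group can be exchanged without loss, and the step is a 3.6-fold lower number from compound 1 to compound 4 (0.56 log units; beyond the scatter), so with the fluoro group kept, a carbonyl at this position is not required for a low number. Among these compounds, the only earlier change here, a 2.3-fold higher number from compound 2 to compound 3 (0.37 log units; beyond the scatter), lengthened the chain on the ester with the carbonyl in place and with no fluoro group on the ring; it moved the number up, whereas this first replacement of the entire group, by the smaller propargyloxy, moves it down, so the earlier step gave no guide to the direction of this one. Nothing on hand explains why the number falls with propargyloxy at this position.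

Open, on these data alone, is which part of the exchange carries the step: the loss of the carbonyl or the triple bond, which a saturated propoxy group or an allyloxy group at the same position would help to separate. Also open, as far as these compounds go, is whether the step holds without the fluoro group, and whether a carboxylic acid or a longer alkynyloxy chain at this position would fit the same trend.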